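Moving the Acetyl Group on the Anilino Ring

This account rests on a few compounds, and the source may have more. Where it says the series, first, only, none or still open, it means among the compounds named here.

Of the compounds shown here, two sharing one core have been tested in a functional assay on ACHN cells (Homo sapiens) for inhibition, read by sulforhodamine B assay, with a stated time of 48 h, tested at 10 uM; on this read-out higher numbers stand for more inhibition of growth at the one concentration tested and lower numbers for less inhibition of growth. Compound 1 `CCOC(=O)c1ccc(Nc2ccnc(SCC(=O)c3ccc(C#N)cc3)n2)cc1` gives 20% in this assay. Compound 2 `CC(=O)c1cccc(Nc2ccnc(SCC(=O)c3ccc(-c4ccccc4)cc3)n2)c1` gives 12% in this assay, the lower of the two numbers, though its gap to compound 1 lies within the usual scatter, so the two cannot be ranked against each other. Compound 3 `CC(=O)c1ccc(Nc2ccnc(SCC(=O)c3ccc(-c4ccccc4)cc3)n2)cc1` remains to be measured. It differs from compound 2 in a single place: 4-acetylphenyl in place of 3-acetylphenyl on a nitrogen on an aromatic ring. Among the compounds with values here, no pair of measured compounds isolates this change, and compound 1 carries a different group on that nitrogen altogether, so the comparison rests on the pair of numbers alone. Both measured values are low, and no step beyond the scatter is expected in this assay from compound 2 to compound 3. Compound 3 is therefore estimated at 16%, within a range of 4% to 32%, which amounts to an expected step of a number 4 percentage points higher from compound 2 to compound 3 (within the scatter).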

Compound 3, percent growth inhibition at one concentration: 26%
Compound 3: middle estimate off by 10 percentage points, on the low side, within the range that was stated.
By their numbers in this assay, from the lowest: compounds 2, 1 and 3 (each within the scatter of the next, the first and the last beyond it).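

Among the compounds shown, this is the first change whose effect can be read on its own. With 4-acetylphenyl in place of 3-acetylphenyl on the nitrogen, this assay gives a number 14 percentage points higher from compound 2 to compound 3 (beyond the scatter), so where the acetyl group sits on this ring matters, even though the two groups match in every count of atoms, double bonds, donors and acceptors. No measurement shown here accounts for this step.

Going by these compounds, what remains open is whether this preference extends beyond the acetyl group, for example to a carboxylic acid or an amine on the same ring, and whether it holds when the biphenyl-bearing ketone arm of compound 3 is replaced. Compound 3, at 26%, also leaves open how the series behaves at other concentrations, since only one was tested.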